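The compounds below may be only part of what the source reports. "The series", "measured", "known", "first", "only" and "open" are said of these compounds alone.

Compound 1 `Nc1cc(N)c2nc(-c3ccccc3)c(Oc3ccc(Cl)c(Cl)c3)nc2c1` gives 70800 nM in a functional assay on NCI-H460 cells (Homo sapiens) for inhibition, read by sulforhodamine B assay, with a stated time of 48 h; on this read-out lower numbers stand for stronger inhibition of growth and higher numbers for weaker inhibition of growth.
Compound 2 `CCOC(=O)[C@H](CCC(=O)O)NC(=O)c1ccc(CNc2nc3cc(N)cc(N)c3nc2-c2ccccc2)cc1` gives only a limit of this assay, < 100000 nM, and not a number.
Compound 3 `COc1ccc(CNc2nc3cc(N)cc(N)c3nc2-c2ccccc2)cc1` gives 47900 nM in this assay.

Two numbers are known, and the value of compound 1 and the value of compound 3 lie within the scatter of each other, so neither can be set above the other. For compound 2 the assay reports (the limit of < 100000 nM in this assay, at which 1 of the 3 values shown sits), which is a limit and nothing more, so compound 2 cannot be placed against the other two.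

The unmeasured compound 4 `Nc1cc(N)c2nc(-c3ccccc3)c(Oc3ccc(F)cc3)nc2c1` differs from compound 1 in one place: 4-fluorophenyl in place of 3,4-dichlorophenyl on an oxygen on an aromatic ring. For the measured compounds named here, no pair of measured compounds shows such a swap on the shared core, so no measured step can be read off for it. Without such a step, the expected step from compound 1 to compound 4 in this assay is estimated as a 1.0-fold lower number from compound 1 to compound 4 (0.00 log units; within the scatter), which is no change beyond the scatter. Compound 4 is therefore expected to give about 70000 nM, with a likely range from 25000 nM to 200000 nM.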

Compound 4, concentration for total growth inhibition: < 100000 nM
Compound 4 was reported as a limit; the forecaster's own chance of this, stated with the estimate: 25%; the middle value lies beyond the limit too.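

In this assay compound 4 gives only a limit, < 100000 nM, and not a number. The step from compound 1 to compound 4 therefore cannot be read, and the result stands at the assay's limit: the limit of < 100000 nM in this assay, at which 2 of the 4 values shown sit.

The compounds shown leave open whether 4-fluorophenyl in place of 3,4-dichlorophenyl on an oxygen on an aromatic ring changes growth inhibition at all.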